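The source may report more compounds than this note shows. Statements on the series, on what has been measured and on what is new or still open speak of the compounds shown alone.

Among the measured compounds shown here, compound 1 `COc1cccc(-c2c(C)n(Cc3c(F)cccc3F)c(=O)n([C@@H](C)CNCc3ccccc3)c2=O)c1` gives 370 nM in an assay on HEK293 cells for binding affinity to Gonadotropin-releasing hormone receptor (Homo sapiens) (a higher number here means a weaker inhibitor, a lower number a stronger inhibitor), the lower of the two numbers measured so far. Compound 2 `COc1cccc(-c2c(C)n(Cc3c(F)cccc3F)c(=O)n([C@@H](C)CNCC(C)C)c2=O)c1`, with isopropyl in place of phenyl on a saturated chain carbon bound to an amine nitrogen, gives 1200 nM in this assay; that change brings a 3.2-fold higher number from compound 1 to compound 2 (0.51 log units; beyond the scatter). Compound 3 `COc1cccc(-c2c(C)n(Cc3c(F)cccc3F)c(=O)n([C@@H](C)CNCc3ccccc3F)c2=O)c1` differs from compound 1 by fluoro in place of hydrogen on an aromatic carbon. For the measured compounds named here, no measured step touches the aromatic ring itself; the only step available, a 3.2-fold higher number from compound 1 to compound 2 (0.51 log units; beyond the scatter), shows that exchanging phenyl for isopropyl costs a modest amount, which says little about adding fluoro to the phenyl. Only a small change, if any, is therefore expected in this assay, in either direction. The step expected here is a 1.2-fold lower number from compound 1 to compound 3 (0.06 log units; within the scatter), within the usual scatter. Compound 3 is expected to give 320 nM in this assay, with a range of 120 nM to 900 nM.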

Compound 3, inhibition constant: 550 nM
Estimate against measurement, compound 3: 1.7-fold (0.24 log units) below, within the range that was stated.
By their numbers in this assay, from the lowest: compounds 1 and 3 (each within the scatter of the next); then compound 2.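

In this assay, this is the only step shown that alters the aromatic ring itself: fluoro in place of hydrogen on an aromatic carbon, ortho to a large group, gives a 1.5-fold higher number from compound 1 to compound 3 (0.17 log units; within the scatter). The benzyl and 2-fluorobenzyl groups therefore cannot be told apart at this position, so this carbon accepts a single fluoro without a change that can be read beyond the scatter. The aromatic group also remains better than the isopropyl group once it carries fluoro, with a 2.2-fold lower number from compound 2 to compound 3 (0.34 log units; beyond the scatter), and compounds 1, 2 and 3 show nothing against this.

On these data alone, whether chloro or a nitrile on this same carbon, or fluoro elsewhere on the ring, would move the number stays open. Nothing measured here gives a reason for either step.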